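A few compounds are considered here, and "the series" means these few. Any claim that something is new, unique, unknown or untested is made for them only; others in the source may bear on it.

Compound 3 `COc1cccc(/C=C/C(=O)c2ccc(OC)c([N+](=O)[O-])c2)c1` is, on the numbers shown, one of three compounds that all stop at an assay limit rather than at a measured number. In a functional assay on B16 cells (Mus musculus) for cytotoxicity, read by MTT assay, with a stated time of 3 days (a higher number here means a weaker inhibitor, a lower number a stronger inhibitor), compound 3 gives > 100000 nM, which is a limit of the assay. Compound 1 `COc1ccc(C(=O)/C=C/c2ccccc2)cc1[N+](=O)[O-]` gives > 100000 nM in this assay, again a limit. Compound 2 `COc1ccc(C(=O)/C=C/c2ccccc2)cc1N` gives > 100000 nM in this assay, once more a limit. Because (the limit of > 100000 nM in this assay, at which 3 of the 3 values shown sit), neither the step from compound 1 to compound 2 nor the step from compound 1 to compound 3 can be read: a step that the two limits leave unreadable from compound 1 to compound 2 and a step that the two limits leave unreadable from compound 1 to compound 3.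

Compound 4 `COc1cccc(/C=C/C(=O)c2ccc(OC)c(N)c2)c1` differs from compound 3 in one place: amino in place of nitro on an aromatic carbon. Within the data shown here, the only measured step of the same kind, from compound 1 to compound 2, is unreadable, and nothing measured here separates any of the three compounds from one another. No step beyond the scatter is therefore expected, and compound 4 is expected to remain at the limit, with a step of a number no higher from compound 3 to compound 4 (the limit leaves the size open). Compound 4 is estimated at 100000 nM, with a range from 30000 nM to 300000 nM.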

Compound 4, half-maximal inhibitory concentration: 33000 nM
For compound 4 the middle estimate is 3.0-fold (0.48 log units) above the measured one; low and high end bracket the measured number.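

In this assay, the amino group in place of nitro, at the position ortho to a methoxy group, now gives a readable change: an at least 3.0-fold lower number from compound 3 to compound 4 (0.48 log units; beyond the scatter). With amino in place, methoxy in place of hydrogen also becomes readable: an at least 3.0-fold lower number from compound 2 to compound 4 (0.48 log units; beyond the scatter). The steps between the three earlier compounds still cannot be read, because both ends of each step sit at a limit: the limit of > 100000 nM in this assay, at which 3 of the 4 values shown sit.

As far as these compounds go, the full size of both new steps stays open, since each has only a lower bound. The compounds shown also leave open whether an acetamide or a dimethylamino group at the amino position, or a hydroxy group in place of the added methoxy, would give a lower number still.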